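Thiophene-fused series: aryl swap at the core position

The compounds below may be only part of what the source reports. "The series", "measured", "known", "first", "only" and "open" are said of these compounds alone.

Within the data shown here, the series so far comprises compound 1 `Cc1ccc(-c2nc(N)c3cc(CN4CCCCC4)sc3n2)o1`, compound 2 `Nc1nc(-c2ccc(Br)o2)nc2sc(CN3CCCC3)cc12` and compound 3 `Nc1nc(-c2cc3ccccc3o2)nc2sc(CN3CCC(F)CC3)cc12`, all sharing one core and differing in the aryl group and the amine-bearing chain. In an assay on CHO-K1 cells for antagonist activity at adenosine receptor A1 (Homo sapiens), read by a beta-galactosidase reporter, with stated times of 15 min and 6 h (on this read-out higher numbers stand for weaker inhibition and lower numbers for stronger inhibition), compound 1 gives 610 nM, compound 2 gives 710 nM and compound 3 gives 630 nM. Compound 3 stands second highest of the three numbers, yet its gaps to compound 1 and to compound 2 both lie within the scatter, so no order among them can be read. Compound 4 `Nc1nc(-c2cccc([N+](=O)[O-])c2)nc2sc(CN3CCC(F)CC3)cc12` is not yet measured; it differs from compound 3 by 3-nitrophenyl in place of 1-benzofuran-2-yl on an aromatic carbon. Among the measured compounds shown here, no step between measured compounds is available for this change. Since three different aryl groups give numbers within the scatter of each other, a step no larger than the scatter is expected for compound 4, a 1.4-fold higher number from compound 3 to compound 4 (0.15 log units; within the scatter). Compound 4 is estimated at 900 nM in this assay, within 300 nM to 3000 nM.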

Compound 4, inhibition constant: > 10000 nM
Compound 4: a limit, no number (the forecaster's own chance of this, stated with the estimate: 10%); middle value at least 11-fold (1.04 log units) away from the limit.
By their numbers in this assay, from the lowest: compounds 1, 3 and 2 (each within the scatter of the next). At a limit, above all of these: compound 4.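

Compound 3 and compound 4 differ only at the aromatic carbon between two ring nitrogen atoms, and this assay gives an at least 15-fold higher number from compound 3 to compound 4 (1.20 log units; beyond the scatter). This position is therefore not indifferent to the aryl group, which compound 1, compound 2 and compound 3 could not show, as they also differ in the amine-bearing chain. Compound 4 gives > 10000 nM, a limit and not a number, so the step has no upper end: the limit of > 10000 nM in this assay, at which 1 of the 4 values shown sits.

The compounds shown do not separate the nitro group from the change to a single six-membered aromatic ring. An unsubstituted phenyl or a 3-aminophenyl group at this position would bear on that.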